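The source may hold more compounds than are shown below. What is called first, only, known or untested is meant among the compounds shown, and "the series" means these compounds.

Compound 2 `C=CCn1c(=O)/c(=C\c2ccccc2OC)[nH]c(=O)/c1=C\c1ccccc1OC` and compound 1 `C=CCn1c(=O)/c(=C\c2cc(Br)ccc2F)[nH]c(=O)/c1=C\c1ccccc1OC` share one core and differ only at one aryl group on a double-bonded chain carbon. In a functional assay on HL-60 cells (Homo sapiens) for cytotoxicity, read by CCK-8 assay, with a stated time of 72 h (on this read-out lower numbers stand for stronger inhibition and higher numbers for weaker inhibition), compound 2 gives 15700 nM, and compound 1 gives 17400 nM; the two values sit within the scatter of each other. Compound 3 `C=CCn1c(=O)/c(=C\c2cccc(Br)c2)[nH]c(=O)/c1=C\c1ccccc1OC` carries 3-bromophenyl in place of 2-methoxyphenyl on a double-bonded chain carbon bound to an aromatic carbon. Among the compounds with values here, the one comparable change, a 1.1-fold lower number from compound 1 to compound 2 (0.04 log units; within the scatter), also swapped the aryl group at this place and moved the number little, so for compound 3 no step beyond the scatter is expected in this assay. Compound 3 is therefore estimated at 16000 nM, within 7000 nM to 36000 nM, meaning an expected step of a 1.0-fold higher number from compound 2 to compound 3 (0.01 log units; within the scatter).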

Compound 3, half-maximal inhibitory concentration: 5200 nM
Estimate against measurement, compound 3: 3.1-fold (0.49 log units) above; measured number below the stated range.
By their numbers in this assay, from the lowest: compound 3; then compounds 2 and 1 (each within the scatter of the next).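

In this assay, this place on the double-bonded chain carbon proves sensitive to the aryl group: 3-bromophenyl in place of 2-methoxyphenyl gives a 3.0-fold lower number from compound 2 to compound 3 (0.48 log units; beyond the scatter), a step beyond the scatter, unlike the earlier swap. Bromine is present in both compound 1 and compound 3, and hydrogen in place of fluoro gives a 3.3-fold lower number from compound 1 to compound 3 (0.52 log units; beyond the scatter), so a single fluoro separates these two compounds. Nothing measured here explains either step. As far as these compounds go, it remains open whether a plain phenyl or a 3-chlorophenyl at this place would match compound 3, and therefore what the bromine contributes.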